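A few compounds are considered here, and "the series" means these few. Any claim that something is new, unique, unknown or untested is made for them only; others in the source may bear on it.

Measured in a functional assay on MDA-MB-231 cells (Homo sapiens) for antiproliferative activity, read by MTT assay; on this read-out lower numbers stand for stronger inhibition and higher numbers for weaker inhibition:
- compound 1 `CCCC/C=C\CCCCCCCCCc1cc(=O)c2c(O)cc(OCOC)cc2o1`: > 87000 nM
- compound 2 `CC/C=C\C/C=C\C/C=C\CCCCCCCc1cc(=O)c2c(O)cc(O)cc2o1`: 6790 nM

Compound 1 stands at a limit of this assay, not at a number: > 87000 nM. Compound 2 has a true number, 6790 nM.

Compound 3 `CCCC/C=C\CCCCCCCCCc1cc(=O)c2c(O)c(C)c(OCOC)cc2o1` keeps the core and chain of compound 1 and carries one change, methyl in place of hydrogen on an aromatic carbon, ortho to a hydroxy group and ortho to a methoxymethoxy group: methyl in place of hydrogen on an aromatic carbon. Among the compounds with values here, no measured pair isolates this change. The expectation therefore starts from the limit alone, and no step beyond the scatter is expected in this assay, in either direction. The estimated step is a step that the limit leaves unreadable from compound 1 to compound 3. A report of compound 3 as another limit would be no surprise. For compound 3 the expected value is 90000 nM, with an estimated range of 35000 nM to 200000 nM.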

Compound 3, half-maximal inhibitory concentration: > 87000 nM
Compound 3 ended at the assay's limit; the forecaster's own chance of this, stated with the estimate: 70%; the middle value is on the limit's open side.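

No step can be read from compound 1 to compound 3: in this assay each compound stands at a limit, not at a number: the limit of > 87000 nM in this assay, at which 2 of the 3 values shown sit.

The compounds shown leave open whether methyl in place of hydrogen on an aromatic carbon changes inhibition at all, in either direction.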